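A few compounds are considered here, and "the series" means these few. Any claim that something is new, unique, unknown or untested is made for them only; others in the source may bear on it.

In a functional assay on HT-29 cells (Homo sapiens) for inhibition, read by MTT assay, with a stated time of 48 h (on this read-out higher numbers stand for weaker inhibition and lower numbers for stronger inhibition), three compounds have been measured: compound 1 `Cc1ccc(NC(=S)NC(=O)c2ccc(OCc3cccc(Cl)c3)cc2)cc1-c1nc2ccccc2[nH]1` gives 35300 nM, compound 2 `Cc1ccc(NC(=S)NC(=O)c2ccc(OCc3ccc(C(F)(F)F)cc3)cc2)cc1-c1nc2ccccc2[nH]1` gives 17600 nM, and compound 3 `Cc1ccc(NC(=S)NC(=O)c2ccc(OCc3cccc(C(F)(F)F)c3)cc2)cc1-c1nc2ccccc2[nH]1` gives 8200 nM.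

Compound 3 holds the lowest number of the three, with a 2.1-fold lower number from compound 2 to compound 3 (0.33 log units; beyond the scatter) and a 4.3-fold lower number from compound 1 to compound 3 (0.63 log units; beyond the scatter). Compound 4 `Cc1ccc(NC(=S)NC(=O)c2ccc(OCc3cccc(F)c3)cc2)cc1-c1nc2ccccc2[nH]1` differs from compound 3 by fluoro in place of trifluoromethyl on an aromatic carbon. Among the measured compounds shown here, no measured compound carries fluoro at that aromatic carbon, so the closest guide is the earlier exchange of chloro for trifluoromethyl there, a 4.3-fold lower number from compound 1 to compound 3 (0.63 log units; beyond the scatter), which lowered the number. The other steps, a 2.0-fold lower number from compound 1 to compound 2 (0.30 log units; within the scatter) and a 2.1-fold lower number from compound 2 to compound 3 (0.33 log units; beyond the scatter), change where the group sits and bear less directly. Removing trifluoromethyl is therefore expected to raise the number, by roughly a 3.0-fold higher number from compound 3 to compound 4 (0.48 log units; beyond the scatter). Compound 4 is estimated at 25000 nM, within a range of 10000 nM to 60000 nM.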

Compound 4, half-maximal inhibitory concentration: 55300 nM
Estimate against measurement, compound 4: 2.2-fold (0.34 log units) below; the range from low to high includes it.
By their numbers in this assay, from the lowest: compound 3; then compounds 2, 1 and 4 (each within the scatter of the next, the first and the last beyond it).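

In this assay, fluoro in place of trifluoromethyl on this aromatic carbon gives a 6.7-fold higher number from compound 3 to compound 4 (0.83 log units; beyond the scatter), a larger change than the earlier exchange of chloro for trifluoromethyl. Fluoro and chloro cannot be told apart here, with a 1.6-fold higher number from compound 1 to compound 4 (0.19 log units; within the scatter), so among these three groups at this place, only trifluoromethyl lowers the number. The 4-(trifluoromethyl)phenyl compound also stays ahead of the 3-fluorophenyl compound, with a 3.1-fold higher number from compound 2 to compound 4 (0.50 log units; beyond the scatter).

No available measurement explains these steps. From the compounds shown here alone, whether a methoxy group, a nitrile or an amine on this carbon would match trifluoromethyl remains open.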